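Swapping a trifluoromethyl for a methoxy on the carbonyl

The compounds below may be only part of what the source reports. "The series", "measured", "known", "first", "only" and "open" are said of these compounds alone.

Of the compounds shown here, three sharing one core have been measured in an assay for inhibition of Fatty-acid amide hydrolase 1 (Rattus norvegicus); on this read-out higher numbers stand for weaker inhibition and lower numbers for stronger inhibition. Compound 1 `N#Cc1cccc(-c2cnc(C(=O)CCc3ccc(-c4ccccc4)cc3)o2)n1` gives 2.9 nM, compound 2 `NC(=O)c1ccc(-c2cnc(C(=O)CCc3ccc(-c4ccccc4)cc3)o2)nc1` gives 1.3 nM, and compound 3 `O=C(CCc1ccc(-c2ccccc2)cc1)c1ncc(C(=O)C(F)(F)F)o1` gives 8 nM, the highest of the three numbers. The steps to it are a 2.8-fold higher number from compound 1 to compound 3 (0.44 log units; beyond the scatter) and a 6.2-fold higher number from compound 2 to compound 3 (0.79 log units; beyond the scatter). Compound 4 `COC(=O)c1cnc(C(=O)CCc2ccc(-c3ccccc3)cc2)o1` differs from compound 3 in one place: methoxy in place of trifluoromethyl on a carbonyl carbon. Within the data shown here, no measured step changes only this part of the molecule, so the two steps into compound 3 offer no direct guide, and the expectation rests on the change itself. A modest rise in this assay, beyond the scatter, is expected for compound 4, namely a 2.5-fold higher number from compound 3 to compound 4 (0.40 log units; beyond the scatter). The estimated value for compound 4 is 20 nM, within 5 nM to 80 nM.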

Compound 4, inhibition constant: 1.5 nM
Compound 4: the middle estimate sits 13-fold (1.12 log units) above what was measured; the measured number lies below the stated range.
By their numbers in this assay, from the lowest: compounds 2, 4 and 1 (each within the scatter of the next, the first and the last beyond it); then compound 3.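

In this assay, methoxy on this carbonyl carbon gives stronger inhibition than trifluoromethyl, with a 5.3-fold lower number from compound 3 to compound 4 (0.73 log units; beyond the scatter), so the trifluoromethyl is not needed for a low number here. The methoxycarbonyl group also matches both pyridine-bearing groups on the aromatic carbon, with a 1.2-fold higher number from compound 2 to compound 4 (0.06 log units; within the scatter) and a 1.9-fold lower number from compound 1 to compound 4 (0.29 log units; within the scatter). No measured evidence accounts for the gain from methoxy. Still open, going by these compounds, is how a hydroxyl, as in a carboxylic acid, an amine, as in a primary amide, or the longer ethoxy chain would fare on this carbonyl carbon.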